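A few compounds are considered here, and "the series" means these few. Any claim that something is new, unique, unknown or untested is made for them only; others in the source may bear on it.

Two ureas share one core and differ only in the group on the fused ring system. Compound 1 `O=C(Nc1ccc(-n2ncc3c(C(F)(F)F)cccc32)cc1)Nc1ccc(Cl)c(C(F)(F)F)c1` carries a trifluoromethyl there, while compound 2 `O=C(Nc1ccc(-n2ncc3c(Cl)cccc32)cc1)Nc1ccc(Cl)c(C(F)(F)F)c1` carries a chloro in its place. In a functional assay on SGC-7901 cells (Homo sapiens) for cytotoxicity, read by MTT assay, with a stated time of 72 h (a higher number here means a weaker inhibitor, a lower number a stronger inhibitor), compound 1 gives only a limit, > 32000 nM, and no number. In this assay compound 2 gives 4600 nM. The step of an at least 6.9-fold lower number from compound 1 to compound 2 (0.84 log units; beyond the scatter) is the only measured change, so compound 2 holds the single full number shown, the other result sitting at the limit of the measurement (the limit of > 32000 nM in this assay, at which 1 of the 2 values shown sits).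

Compound 3 `COc1cccc2c1cnn2-c1ccc(NC(=O)Nc2ccc(Cl)c(C(F)(F)F)c2)cc1` differs from compound 2 in one place: methoxy in place of chloro on an aromatic carbon. Among the measured compounds shown here, no measured step swaps chloro for methoxy, so the step of a 1.7-fold higher number from compound 2 to compound 3 (0.24 log units; within the scatter) expected here rests on little. For the measured compounds named here, the one measured step shows that a change at this group can move the number beyond the scatter, so a shift in either direction is possible; with no closer precedent, the expectation stays near the value of compound 2 but with wide bounds. Compound 3 is therefore expected near 8000 nM, within a range from 2000 nM to 32000 nM.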

Compound 3, half-maximal inhibitory concentration: 29800 nM
Compound 3: middle estimate off by 3.7-fold (0.57 log units), on the low side, within the range that was stated.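

Replacing chloro with methoxy on this aromatic carbon modestly weakens the compound: this assay gives a 6.5-fold higher number from compound 2 to compound 3 (0.81 log units; beyond the scatter). Until now, only the change from trifluoromethyl to chloro had been seen, as an at least 6.9-fold lower number from compound 1 to compound 2 (0.84 log units; beyond the scatter), so it was unknown whether chloro would also outperform a different group; compound 2 now stands as the most potent of the three, with both replacements giving a higher number. This leaves only a floor for the remaining step, an at least 1.0-fold lower number from compound 1 to compound 3 (0.03 log units; that floor lies within the scatter), because one of its two results is a limit and no number: the limit of > 32000 nM in this assay, at which 1 of the 3 values shown sits.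

On these data alone, what an amine, a fluoro or a plain hydrogen on this aromatic carbon would give stays open, as does whether any group can improve on compound 2, which gives 4600 nM. Also open, as far as these compounds go, is whether chloro would keep its lead over methoxy and trifluoromethyl if the rest of the shared core were changed.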